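The source may hold more compounds than are shown below. What is called first, only, known or untested is meant among the compounds shown, and "the series" means these compounds.

Working notes on the series.

Three compounds have numbers in an ADME assay on microsomes from liver (Homo sapiens) for metabolic stability, tested at 2.5 uM; a higher number here means faster removal of the compound, a lower number slower removal. Compound 1 `COc1ccc(-c2c(S(=O)(=O)c3cc(Cl)cc(Cl)c3)cnc3c(F)cccc23)cc1` gives 2.11 mL/min in this assay. Compound 2 `COc1cccc(-c2c(S(=O)(=O)c3cc(Cl)cc(Cl)c3)cnc3c(F)cccc23)c1` gives 2.31 mL/min in this assay. Compound 3 `COc1cccc(-c2c(S(=O)(=O)c3ccc(F)cc3)cnc3c(F)cccc23)c1` gives 2.23 mL/min in this assay. All three sit within the usual scatter of one another, so no order among them is claimed.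

Compound 2 and compound 1 differ by 4-methoxyphenyl in place of 3-methoxyphenyl on an aromatic carbon; the step in this assay is a 1.1-fold lower number from compound 2 to compound 1 (0.04 log units; within the scatter). The cores of compound 2 and compound 3 differ by 4-fluorophenyl in place of 3,5-dichlorophenyl on a sulfonyl sulfur, and the step in this assay is a 1.0-fold lower number from compound 2 to compound 3 (0.02 log units; within the scatter). Neither change moved the read-out beyond the scatter.

Compound 4 `COc1ccc(-c2c(S(=O)(=O)c3ccc(F)cc3)cnc3c(F)cccc23)cc1` has no number yet in this assay. It differs from compound 3 by 4-methoxyphenyl in place of 3-methoxyphenyl on an aromatic carbon. This is the same change as that from compound 2 to compound 1, made here on the core of compound 3, which carries 4-fluorophenyl on the sulfonyl sulfur in place of 3,5-dichlorophenyl. The place description is identical word for word in both cases.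

The step from compound 3 to compound 4 in this assay is expected to be a 1.1-fold lower number from compound 3 to compound 4 (0.04 log units; within the scatter), a step of about the same size as a 1.1-fold lower number from compound 2 to compound 1 (0.04 log units; within the scatter); the expectation rests on the value of compound 2, 2.31 mL/min, and the value of compound 1, 2.11 mL/min, which lie within the scatter of each other, and on compound 3 with 2.23 mL/min as the starting point.

Compound 4 is therefore estimated to give about 2.05 mL/min in this assay, with an expected range from 1.4 mL/min to 3 mL/min.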

Compound 4, intrinsic clearance in a liver preparation (reported as CLH), per the amount of preparation that the assay uses: 2.41 mL/min
Estimate against measurement, compound 4: 1.2-fold (0.07 log units) below; measured number inside the range.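

The two changes can now each be read on two cores. On the core of compound 3, 4-methoxyphenyl in place of 3-methoxyphenyl on an aromatic carbon gives (a 1.1-fold higher number from compound 3 to compound 4 (0.03 log units; within the scatter)) in this assay, and this step stands within the scatter of the earlier one: the same change on two cores in this assay, a 1.1-fold lower number (0.04 log units; within the scatter) from compound 2 to compound 1 and a 1.1-fold higher number (0.03 log units; within the scatter) from compound 3 to compound 4, 1.2-fold (0.07 log units) apart, within the scatter of two such steps. On the core of compound 1, 4-fluorophenyl in place of 3,5-dichlorophenyl on a sulfonyl sulfur gives (a 1.1-fold higher number from compound 1 to compound 4 (0.06 log units; within the scatter)), again without a gap beyond the scatter: the same change on two cores in this assay, a 1.0-fold lower number (0.02 log units; within the scatter) from compound 2 to compound 3 and a 1.1-fold higher number (0.06 log units; within the scatter) from compound 1 to compound 4, 1.2-fold (0.07 log units) apart, within the scatter of two such steps. Going by these compounds alone, this shows that neither change moved the read-out beyond the scatter on either core, but it does not show that a real effect carries from one core to another, since no step here stands clear of the scatter, and the four compounds say nothing about cores beyond these.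

As far as these compounds go, whether any change at these two places can move the read-out beyond the scatter remains open, for example an amine or a carboxylic acid in place of the methoxy group on the aromatic ring. Also open, from the compounds shown here alone, is whether a longer chain in place of that methoxy group would behave alike on the cores of compound 1 and compound 3.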